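A Methyl-to-Trifluoromethyl Swap Tested on Two Cores

This account rests on a few compounds, and the source may have more. Where it says the series, first, only, none or still open, it means among the compounds named here.

Of the compounds shown here, three have been measured so far in a functional assay on SK-LU-1 cells (Homo sapiens) for cytotoxicity, read by sulforhodamine B assay, with a stated time of 48 h, tested at 50 uM; a lower number here means less inhibition, a higher number more inhibition at the concentration tested (going by the name of the read-out). Compound 1 `Cc1ccc(Nc2nccc(-c3ccnc4ccccc34)n2)cc1` gives 100%. Compound 2 `FC(F)(F)c1ccc(Nc2nccc(-c3ccnc4ccccc34)n2)cc1` shares the core of compound 1 and differs from it in one place: trifluoromethyl in place of methyl on an aromatic carbon. In this assay compound 2 gives 100%, and the step recorded is no change at the digits printed from compound 1 to compound 2 (within the scatter). Compound 3 `Cc1ccc(Nc2nccc(-c3c(C)nc4ccccn34)n2)cc1` carries a different core; the difference between the two cores is not broken down here. In this assay compound 3 gives 100%, which sits level with compound 1 and compound 2 within the usual scatter.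

Compound 4 `Cc1nc2ccccn2c1-c1ccnc(Nc2ccc(C(F)(F)F)cc2)n1` has not yet been measured. It stands to compound 3 exactly as compound 2 stands to compound 1: trifluoromethyl in place of methyl on an aromatic carbon. The place of the change is described in the same words for both pairs, so this is the same change made on a second core. It occurs twice among the four compounds.

The step expected from compound 3 to compound 4 is no change at the digits printed from compound 3 to compound 4 (within the scatter), placed beside the earlier step of no change at the digits printed from compound 1 to compound 2 (within the scatter). This rests on one observation only: the same change left the read-out unmoved in the step of no change at the digits printed from compound 1 to compound 2 (within the scatter), and compound 3 already sits at 100%, leaving no room for the read-out to climb. Compound 4 is therefore expected to give about 100%, with a range from 90% to 100%.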

Compound 4, a percentage reported as inhibition, at one concentration (the size of the read-out at that concentration, not a potency): 100%
Estimate against measurement, compound 4: no gap at the digits printed; the range from low to high includes it.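

The new step reads no change at the digits printed from compound 3 to compound 4 (within the scatter), and in this assay it agrees with the step made by the same swap on the other core: the same change on two cores in this assay, no change at the digits printed (within the scatter) from compound 1 to compound 2 and no change at the digits printed (within the scatter) from compound 3 to compound 4, 0 percentage points apart, within the scatter of two such steps. Within these two pairs, then, putting trifluoromethyl in place of methyl on the aromatic carbon gave the same outcome on both cores, a level read-out. This does not show that the swap makes no difference to how strongly the compounds act, since compound 4 gives 100%, as do the other three compounds, so inhibition is already complete at the one concentration tested and any difference in potency between them would stay hidden; two pairs also cannot establish a rule for the wider series.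

The compounds shown leave open whether the pairs would still match at a concentration where inhibition is only partial, which is where a true difference between methyl and trifluoromethyl could appear. They also leave open whether another group at the same place on the ring, such as an amine, a carboxylic acid or a longer chain, would keep the read-out level on both cores.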